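A few compounds are considered here, and "the series" means these few. Any claim that something is new, unique, unknown or untested is made for them only; others in the source may bear on it.

In an assay on HEK293 cells for displacement of a labelled ligand from 5-hydroxytryptamine receptor 3A (Homo sapiens), read by scintillation counting, with a stated time of 24 h, in the presence of a further agent that is not named here (a higher number here means a weaker inhibitor, a lower number a stronger inhibitor), the measured compounds are:
compound 1 `CNc1nc(N2CC[C@H](N)C2)nc2ccc(Cl)cc12` — 2340 nM
compound 2 `CN1CCN(c2cnc3ccccc3c2)CC1` — 407 nM
compound 3 `CN1CCN(c2cc3ccccc3c(N)n2)CC1` — 219 nM

Compound 3 has the lowest number of the three. Compound 2 lies within the scatter of it, so no order between these two is claimed; compound 1 sits well beyond the scatter, with the higher number. Compound 4 `CNc1nc(N2CCN(C)CC2)cc2ccccc12` is not yet measured and differs from compound 3 by methyl in place of hydrogen on a nitrogen on an aromatic ring. Among the measured compounds shown here, no measured pair shows this change on its own; compound 1 carries a methylamino group, but it differs from compound 3 in several further places, so its number gives no direct anchor. With nothing to calibrate the change, the step in this assay is expected to be small, with no clear direction beyond the scatter. The expected step is a 1.4-fold higher number from compound 3 to compound 4 (0.14 log units; within the scatter). Compound 4 is estimated at 300 nM, with a range from 100 nM to 900 nM.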

Compound 4, inhibition constant: 5.89 nM
The estimate for compound 4 lay 51-fold (1.71 log units) above the measured number; the measured number lies below the stated range.
By their numbers in this assay, from the lowest: compound 4; then compounds 3 and 2 (each within the scatter of the next); then compound 1.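

In this assay, methyl in place of hydrogen on a nitrogen on an aromatic ring gives a 37-fold lower number from compound 3 to compound 4 (1.57 log units; beyond the scatter). This nitrogen is therefore a sensitive place in the series: amino to methylamino, a change of a single carbon, moves the number well beyond the scatter, which no earlier comparison could show. Nothing shown accounts for the size of this step. On these data alone, whether an ethylamino or a dimethylamino group at this place goes further or reverses the step stays open. So does whether the same step holds on a different core.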